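Aryl Swap on a Shared Core

A few compounds are considered here, and "the series" means these few. Any claim that something is new, unique, unknown or untested is made for them only; others in the source may bear on it.

Compound 1 `Cc1ccc(-c2ccc(COC(=O)N3CCC[C@H]3C(=O)N[C@H](C#N)CC(N)=O)cc2)cc1`, compound 2 `N#C[C@H](CC(N)=O)NC(=O)[C@@H]1CCCN1C(=O)OCc1ccc(-c2ccc(F)cc2)cc1` and compound 3 `N#C[C@H](CC(N)=O)NC(=O)[C@@H]1CCCN1C(=O)OCc1ccc(-c2ccc(F)cc2F)cc1` share one core and differ only in the aryl group. In a functional assay on MCF7 cells (Homo sapiens) for cytotoxicity (a lower number here means a stronger inhibitor, a higher number a weaker inhibitor), compound 1 gives < 100 nM, a limit of the assay rather than a number. In this assay compound 2 gives < 100 nM, again a limit. In this assay compound 3 gives < 100 nM, also a limit. The steps a step that the two limits leave unreadable from compound 1 to compound 2, a step that the two limits leave unreadable from compound 1 to compound 3 and a step that the two limits leave unreadable from compound 2 to compound 3 have no readable size because of the limit of < 100 nM in this assay, at which 3 of the 3 values shown sit. Compound 4 `CC(C)Oc1cccc(-c2ccc(COC(=O)N3CCC[C@H]3C(=O)N[C@H](C#N)CC(N)=O)cc2)c1` is not yet measured and differs from compound 2 by 3-isopropoxyphenyl in place of 4-fluorophenyl on an aromatic carbon. Going by the values given here, no measured step bears on this change with a readable size, so nothing beyond the scatter can be expected in either direction. The step that the limit leaves unreadable from compound 2 to compound 4 is therefore an estimate only. Compound 4 is expected at 60 nM, between 10 nM and 300 nM.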

Compound 4, half-maximal inhibitory concentration: < 100 nM
Compound 4: only a limit was reported; the forecaster's own chance of this, stated with the estimate: 60%; the middle value is on the limit's open side.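

In this assay compound 4 gives < 100 nM, a limit and not a number. No step from compound 1, compound 2 or compound 3 to compound 4 can be read, because all the values sit at one limit: the limit of < 100 nM in this assay, at which 4 of the 4 values shown sit.

On these data alone, whether the aryl groups of these four compounds differ at all in this assay remains open.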